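The source may report more compounds than this note shows. Statements on the series, on what has been measured and on what is new or still open speak of the compounds shown alone.

Working notes on the thienopyrimidinone series, as read in an assay on cells for inhibition of high affinity 3',5'-cyclic-AMP phosphodiesterase 7A (Homo sapiens), read by scintillation counting and cAMP accumulation, with a stated time of 30 min; on this read-out lower numbers stand for stronger inhibition and higher numbers for weaker inhibition.

Three compounds carry numbers. Compound 1 `CCn1c(NC(C)(C)C)nc2ccsc2c1=O` gives 1500 nM in this assay. Compound 2 `CCn1c(CC(C)C)nc2ccsc2c1=O` gives 4700 nM. Compound 3 `CCn1c(NC2CCOCC2)nc2ccsc2c1=O` gives 430 nM, the lowest number of the three, with its nearest neighbour being compound 1 and its furthest compound 2. The two measured steps: a 3.1-fold higher number from compound 1 to compound 2 (0.50 log units; beyond the scatter), and a 3.5-fold lower number from compound 1 to compound 3 (0.54 log units; beyond the scatter).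

Compound 4 `CCCNc1nc2ccsc2c(=O)n1CC` is not yet measured. Its difference from compound 3 is propyl in place of oxan-4-yl on a nitrogen on an aromatic ring. Going by the values given here, the step that bears on this is the one from compound 1 to compound 3, since both changes sit on the same nitrogen; it was of modest size and moved the number down when oxan-4-yl replaced tert-butyl. Propyl carries neither the ring nor the acceptor of oxan-4-yl, so part of that gain is expected to be given back, and the step is expected to run upward, a 2.3-fold higher number from compound 3 to compound 4 (0.37 log units; beyond the scatter), on the strength of compound 1 at 1500 nM as the nearest reference. The expected value for compound 4 in this assay is 1000 nM, within the range 350 nM to 3000 nM.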

Compound 4, half-maximal inhibitory concentration in the high affinity 3',5'-cyclic-AMP phosphodiesterase 7A assay: 1400 nM
Compound 4: middle estimate off by 1.4-fold (0.15 log units), on the low side; measured number inside the range.
By their numbers in the high affinity 3',5'-cyclic-AMP phosphodiesterase 7A assay, from the lowest: compound 3; then compounds 4 and 1 (each within the scatter of the next); then compound 2.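

In the high affinity 3',5'-cyclic-AMP phosphodiesterase 7A assay, propyl in compound 4 at 1400 nM and tert-butyl in compound 1 at 1500 nM are not separated (a 1.1-fold lower number from compound 1 to compound 4 (0.03 log units; within the scatter)), whereas oxan-4-yl in compound 3 at 430 nM stands apart from propyl (a 3.3-fold higher number from compound 3 to compound 4 (0.51 log units; beyond the scatter)) and from tert-butyl (a 3.5-fold lower number from compound 1 to compound 3 (0.54 log units; beyond the scatter)), so among these three groups only oxan-4-yl gives steps beyond the scatter. On the aromatic carbon, propylamino in place of isobutyl gives (a 3.4-fold lower number from compound 2 to compound 4 (0.53 log units; beyond the scatter)), a second pair alongside (a 3.1-fold higher number from compound 1 to compound 2 (0.50 log units; beyond the scatter)) in which the isobutyl compound carries the higher number. In a physicochemical assay for solubility, in phosphate buffer, at pH 6.8 (a lower number here means a less soluble compound, a higher number a more soluble compound), compound 3 gives 37 ug/mL and compound 4 gives 69 ug/mL, and the same change from oxan-4-yl to propyl stays within the scatter (a 1.9-fold higher number from compound 3 to compound 4 (0.27 log units; within the scatter)).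

Nothing available here accounts for these steps. The compounds shown leave open whether the ring or the oxygen of oxan-4-yl goes with the lower number, a question that cyclohexyl on the same nitrogen would address.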